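Extending the Chain Again: An Estimate for Compound 3

A few compounds are considered here, and "the series" means these few. Any claim that something is new, unique, unknown or untested is made for them only; others in the source may bear on it.

- Compound 1 `CCCc1ccc2[nH]c(-c3ccc(OC)cc3)c(C=C(C#N)C#N)c2c1` gives 83 nM as measured
- Compound 2 `CCCCc1ccc2[nH]c(-c3ccc(OC)cc3)c(C=C(C#N)C#N)c2c1` gives 26 nM as measured
- Compound 3 `CCCCCc1ccc2[nH]c(-c3ccc(OC)cc3)c(C=C(C#N)C#N)c2c1` has no measurement yet

Among the compounds with values here, the readings come from a functional assay on MDA-MB-231 cells (Homo sapiens) for antiproliferative activity, with a stated time of 4 days (a lower number here means a stronger inhibitor, a higher number a weaker inhibitor), and so far cover only two compounds. Within the data shown here, of these, compound 2 has the lower number at 26 nM and is therefore the stronger inhibitor, with compound 1 as its only neighbour. Compound 3 differs from compound 2 by one small change methyl in place of hydrogen on a saturated chain carbon, four bonds along the chain from an aromatic carbon in which methyl replaces hydrogen on a saturated chain carbon, four bonds along the chain from an aromatic carbon.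

Among the measured compounds shown here, one measured step bears on this: a 3.2-fold lower number from compound 1 to compound 2 (0.50 log units; beyond the scatter) for the same kind of change made three bonds along the chain. A single step cannot show whether the gain will continue or level off. Resting on a 3.2-fold lower number from compound 1 to compound 2 (0.50 log units; beyond the scatter) alone, a smaller drop in the same direction is expected in this assay and it may not exceed the scatter. The expected size of the change is a 1.4-fold lower number from compound 2 to compound 3 (0.16 log units; within the scatter) on this reasoning. For compound 3 the estimated value is 18 nM (range 6 nM to 55 nM) in this reading.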

Compound 3, half-maximal inhibitory concentration: 42 nM
Compound 3: the middle estimate sits 2.3-fold (0.37 log units) below what was measured; measured number inside the range.
By their numbers in this assay, from the lowest: compounds 2, 3 and 1 (each within the scatter of the next, the first and the last beyond it).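

In this assay, adding the methyl four bonds along the chain gives a 1.6-fold higher number from compound 2 to compound 3 (0.21 log units; within the scatter), so the clear gain from the same kind of change made three bonds along the chain, a 3.2-fold lower number from compound 1 to compound 2 (0.50 log units; beyond the scatter), does not repeat here. Placing ethyl in place of hydrogen on the chain carbon three bonds along gives a 2.0-fold lower number from compound 1 to compound 3 (0.30 log units; within the scatter), which means that the two-carbon extension as a whole cannot be separated from normal assay variation, although the one-carbon extension to compound 2 can. The effect of lengthening this chain is therefore not a steady one across these three compounds, and nothing available here accounts for the difference between the two positions.

Within the data shown here, with only three chain lengths, a level stretch cannot be told apart from the start of a decline, and a longer chain such as hexyl would be needed to separate the two. On these data alone, it also remains open whether this position tolerates something other than a plain carbon chain, such as a branched isopropyl group or a chain ending in an amine or a carboxylic acid.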